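The source may report more compounds than this note shows. Statements on the series, on what has been measured and on what is new or still open speak of the compounds shown alone.

Working notes on a small series of chalcone-linked imidazolones read in a functional assay on SF-295 cells (Homo sapiens) for inhibition; on this read-out lower numbers stand for stronger inhibition of growth and higher numbers for weaker inhibition of growth.

Compound 1 `COc1cc(/C=C/C(=O)c2cccc(-n3cc(-c4ccc(Cl)cc4)[nH]c3=O)c2)cc(OC)c1OC` gives 24300 nM in this assay, the highest of the three numbers recorded. Compound 3 `COc1ccc(-c2cn(-c3cccc(C(=O)/C=C/c4ccc(O)c(OC)c4)c3)c(=O)[nH]2)cc1` sits nearest, with 13900 nM in this assay; the gap to compound 1 is within the scatter, so the two are taken as indistinguishable. Compound 2 `O=C(/C=C/c1cccc(O)c1)c1cccc(-n2cc(-c3ccc(Cl)cc3)[nH]c2=O)c1` is the furthest, with 1790 nM in this assay, a lower number than compound 1 by a gap that lies beyond the scatter. Within the data shown here, no pair among the three differs in only one place, so no single-point step can be read from them.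

The compound that follows is compound 4 `COc1cc(/C=C/C(=O)c2cccc(-n3cc(-c4cc(OC)c(OC)c(OC)c4)[nH]c3=O)c2)cc(OC)c1OC`. It departs from compound 1 by one change: 3,4,5-trimethoxyphenyl in place of 4-chlorophenyl on an aromatic carbon. Among the measured compounds shown here, with no measured pair that isolates this change, and the two compounds that share the trimethoxy-bearing chalcone side of compound 1, namely compound 1 and compound 3, both standing at the high end, the expectation is for a step that stays within the scatter or is small in either direction; the estimated step is a 1.1-fold higher number from compound 1 to compound 4 (0.03 log units; within the scatter). For compound 4 the estimate in this assay is 26000 nM, with a range from 8000 nM to 80000 nM.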

Compound 4, concentration for 50% growth inhibition: 4960 nM
Estimate against measurement, compound 4: 5.2-fold (0.72 log units) above, outside the stated range (below it).
By their numbers in this assay, from the lowest: compound 2; then compound 4; then compounds 3 and 1 (each within the scatter of the next).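

In this assay, 3,4,5-trimethoxyphenyl in place of 4-chlorophenyl on the aromatic carbon of the five-membered ring gives a 4.9-fold lower number from compound 1 to compound 4 (0.69 log units; beyond the scatter), the first single-place step available in this series and one that lies beyond the scatter. Among these compounds, this position, next to the ring nitrogen, therefore responds to the identity of its aryl group, a point the earlier compounds could not show because no two of them differed in only one place. The larger entering group, with 12 heavy atoms against 7 and 3 hydrogen-bond acceptors against 0, also brings a lower number rather than a higher one, so added bulk at this position does not by itself raise the number on this one pair.

On these data alone, whether the same exchange gives a step of similar size with the 3-hydroxyphenyl chalcone side of compound 2 remains open. Also open, as far as these compounds go, is how this position would respond to an aryl ring carrying an amine or a carboxylic acid. Nothing measured here bears on the origin of the step.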